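The source may report more compounds than this note shows. Statements on the series, on what has been measured and on what is new or still open speak of the compounds shown alone.

Working notes on the series built on the core of compound 1 `Cc1cn([C@@H]2O[C@H](CO[Si](C)(C)C(C)(C)C)[C@@]3(OS(=O)(=O)C=C3NCCC(=O)OCc3ccccc3)[C@H]2O[Si](C)(C)C(C)(C)C)c(=O)n(C)c1=O`. In a functional assay on MT4 cells (Homo sapiens) (a higher number here means that more compound is tolerated, a lower number that less compound is tolerated), compound 1 gives > 250000 nM, which is a limit of the assay rather than a number (the limit of > 250000 nM in this assay, at which 1 of the 3 values shown sits). Compound 2 `CCOC(=O)CNC(=O)NC1=CS(=O)(=O)O[C@@]12[C@@H](CO[Si](C)(C)C(C)(C)C)O[C@@H](n1cc(C)c(=O)n(C)c1=O)[C@@H]2O[Si](C)(C)C(C)(C)C` gives 3780 nM in this assay, and compound 3 `Cc1cn([C@@H]2O[C@H](CO[Si](C)(C)C(C)(C)C)[C@@]3(OS(=O)(=O)C=C3NCC(=O)O)[C@H]2O[Si](C)(C)C(C)(C)C)c(=O)n(C)c1=O` gives 30000 nM. The measured steps are an at least 66-fold lower number from compound 1 to compound 2 (1.82 log units; beyond the scatter), an at least 8.3-fold lower number from compound 1 to compound 3 (0.92 log units; beyond the scatter) and a 7.9-fold higher number from compound 2 to compound 3 (0.90 log units; beyond the scatter). Compound 4 `Cc1cn([C@@H]2O[C@H](CO[Si](C)(C)C(C)(C)C)[C@@]3(OS(=O)(=O)C=C3NCC(=O)C(=O)O)[C@H]2O[Si](C)(C)C(C)(C)C)c(=O)n(C)c1=O` is not yet measured and differs from compound 1 as follows: carboxycarbonyl in place of (benzyloxycarbonyl)methyl on a saturated chain carbon bound to an amine nitrogen. Within the data shown here, the step that bears most directly on it is the one from compound 1 to compound 3, where the free acid also replaces the (benzyloxycarbonyl)methyl and the number falls by at least a modest amount; the larger step to compound 2 runs in the same downward direction. A step of roughly the size seen for compound 3 is expected for compound 4, estimated as an at least 8.3-fold lower number from compound 1 to compound 4 (0.92 log units; beyond the scatter). Compound 4 is therefore estimated at 30000 nM, within a range from 8000 nM to 150000 nM.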

Compound 4, half-maximal cytotoxic concentration: 31100 nM
Beside the measured number, compound 4's estimate is 1.0-fold (0.02 log units) below it, and the stated range covers the measured number.
By their numbers in this assay, from the lowest: compound 2; then compounds 3 and 4 (each within the scatter of the next). At a limit, above all of these: compound 1.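

Compound 3 and compound 4 stand level in this assay, with a 1.0-fold higher number from compound 3 to compound 4 (0.02 log units; within the scatter), so carboxy in place of hydroxy on a carbonyl carbon of this side chain leaves the reading within the scatter. The second free acid also repeats the gaps seen with compound 3, with an 8.2-fold higher number from compound 2 to compound 4 (0.92 log units; beyond the scatter) and an at least 8.0-fold lower number from compound 1 to compound 4 (0.90 log units; beyond the scatter). The value of compound 1 is a limit, so the step from it is only a bound: the limit of > 250000 nM in this assay, at which 1 of the 4 values shown sits.

Open, on these data alone, is whether the free acid itself sets the reading at this position, which a methyl ester or a primary amide on the same chain would test. Also open, as far as these compounds go, is how a longer chain ending in a carboxylic acid, or a chain ending in an amine, would read in this assay.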